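The source may hold more compounds than are shown below. What is called first, only, known or untested is meant among the compounds shown, and "the series" means these compounds.

Compound 1 `O=C(/C=C/[C@H]1C[C@@H](O)[C@@H](O)C1)Nc1ccccc1`: in an ADME assay on S2 cells (Drosophila melanogaster) for cytotoxicity, read by MTT assay (a higher number here means that more compound is needed for the effect, a lower number that less compound is needed), compound 1 gives > 200000 nM, which is a limit of the assay.
Compound 2 `O=C(/C=C/[C@H]1C[C@@H](O)[C@@H](O)C1)Nc1ccc(Cl)cc1`: in this assay compound 2 gives > 180000 nM, again only a limit.
Compound 3 `Cc1ccc(NC(=O)/C=C/[C@H]2C[C@@H](O)[C@@H](O)C2)cc1`: in this assay compound 3 gives > 190000 nM, also a limit.

Compound 3 thus stands at a limit, and the two other values are limits as well. The steps a step that the two limits leave unreadable from compound 1 to compound 2, a step that the two limits leave unreadable from compound 1 to compound 3 and a step that the two limits leave unreadable from compound 2 to compound 3 remain unreadable because both ends of each sit at the limit of > 180000 nM in this assay, at which 1 of the 3 values shown sits, the limit of > 190000 nM in this assay, at which 1 of the 3 values shown sits, or (the limit of > 200000 nM in this assay, at which 1 of the 3 values shown sits). Compound 4 `CC(C)(C)c1ccc(NC(=O)/C=C/[C@H]2C[C@@H](O)[C@@H](O)C2)cc1` differs from compound 3 by tert-butyl in place of methyl on an aromatic carbon. All three measured steps concern a group on the same aromatic carbon, yet none gives a readable size, so no step beyond the scatter can be expected in this assay. Compound 4 is therefore estimated at 200000 nM, within 100000 nM to 400000 nM, an expected step that the limit leaves unreadable from compound 3 to compound 4.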

Compound 4, half-maximal effective concentration: > 180000 nM
Compound 4: no number, only a limit; the forecaster's own chance of this, stated with the estimate: 85%; the middle value is on the limit's open side.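

Compound 4 also stands only at a limit in this assay, so its steps from compound 1, compound 2 and compound 3 cannot be read. The compounds shown leave open whether any group at this aromatic carbon changes the read-out at all.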